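Swapping Fluoromethyl for Hydroxymethyl in a HeLa Cytotoxicity Series

The source may hold more compounds than are shown below. What is called first, only, known or untested is meant among the compounds shown, and "the series" means these compounds.

Of the compounds shown here, two sharing one core have been measured so far in a functional assay on HeLa cells (Homo sapiens) for cytotoxicity, read by WST assay, with a stated time of 48 h; a higher number here means a weaker inhibitor, a lower number a stronger inhibitor. Compound 1 `COc1cc(C(c2ccc(O)c(OC)c2)[C@@H](C)[C@@H](C)CO)ccc1O` reads > 100000 nM, which is a limit of the assay and not a number. Among the compounds with values here, compound 2 `COc1cc(C(c2ccc(O)c(OC)c2)[C@H](C)[C@@H](C)CF)ccc1O` gives 34000 nM, the only actual number, and so it stands on the stronger side of the pair. Within the data shown here, the single measured step is an at least 2.9-fold lower number from compound 1 to compound 2 (0.46 log units; beyond the scatter). Its size is bounded on one side only, so it shows a minimum and not a full measure of the change.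

Compound 3 `COc1cc(C(c2ccc(O)c(OC)c2)[C@H](CO)C(C)C)ccc1O` is the next to be read. The structural change is 1-(hydroxymethyl)-2-methylpropyl in place of 2-(fluoromethyl)-1-methylpropyl on a saturated chain carbon bound to two aromatic carbons. The fluorine thus leaves again, and a hydroxymethyl group returns in a differently branched chain, on the same saturated chain carbon bound to two aromatic carbons.

Among the measured compounds shown here, compound 1 also carries a hydroxymethyl group, and an at least 2.9-fold lower number from compound 1 to compound 2 (0.46 log units; beyond the scatter) is the only guide, so a move back toward a higher number is expected in this assay. The expected change is a 2.6-fold higher number from compound 2 to compound 3 (0.42 log units; beyond the scatter), a modest weakening. For compound 3 the estimated value is 90000 nM, with an expected range from 35000 nM to 250000 nM.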

Compound 3, half-maximal inhibitory concentration: > 100000 nM
Compound 3: only a limit was reported (the forecaster's own chance of this, stated with the estimate: 55%); middle value at least 1.1-fold (0.04 log units) away from the limit.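

Replacing 2-(fluoromethyl)-1-methylpropyl with 1-(hydroxymethyl)-2-methylpropyl on the saturated chain carbon bound to two aromatic carbons gives an at least 2.9-fold higher number from compound 2 to compound 3 (0.46 log units; beyond the scatter) in this assay. Compound 3 reads > 100000 nM, which is a limit of the assay and not a number. Two differently branched chains carrying a hydroxymethyl group, in compound 1 and compound 3, now both end at the limit while the fluorine-bearing chain of compound 2 gives a number, and the step between compound 1 and compound 3 cannot be read, so the two branchings cannot be ordered: the limit of > 100000 nM in this assay, at which 2 of the 3 values shown sit.

The compounds shown leave open whether the number of compound 2 goes with the fluoromethyl group itself or with the branching of its chain, as compound 2 and compound 3 differ in both. A 1-(fluoromethyl)-2-methylpropyl chain would separate the two, and an aminomethyl group or a longer chain on the same carbon would show whether anything other than fluorine gives a number in this series.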